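A few compounds are considered here, and "the series" means these few. Any claim that something is new, unique, unknown or untested is made for them only; others in the source may bear on it.

Of the compounds shown here, three share one core and have been measured in an ADME assay on microsomes from liver (Rattus norvegicus) for metabolic stability; a higher number here means faster removal of the compound, a lower number slower removal. Compound 1 `CC(C)COc1ncc(-c2cc(F)c(-c3nnc(S(=O)(=O)CC4CC4)[nH]3)cc2F)cc1Cl` gives 58 uL/min. Compound 2 `COc1cc(-c2nnc(S(=O)(=O)C3CCC3)[nH]2)ccc1-c1cnc(OCC(C)C)c(Cl)c1` gives 61 uL/min, and compound 3 `CC(C)COc1ncc(-c2cc(F)c(-c3nnc(S(=O)(=O)NC4CC4)[nH]3)cc2F)cc1Cl` gives 54 uL/min. Compound 1 sits among these such that its number lies within the usual scatter of both compound 2 and compound 3, so the three cannot be told apart on this assay. Among the compounds with values here, the one change between measured compounds with a single difference, a 1.1-fold lower number from compound 1 to compound 3 (0.03 log units; within the scatter), confirms that exchanging the group on the sulfonyl sulfur leaves the number essentially where it was.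

Compound 4 `O=S(=O)(CC1CC1)c1nnc(-c2cc(F)c(-c3cnc(Oc4ccc(F)cc4Cl)c(Cl)c3)cc2F)[nH]1` has not yet been measured. It departs from compound 1 at a different place: 2-chloro-4-fluorophenyl in place of isobutyl on an oxygen on an aromatic ring. No measured step touches this oxygen on an aromatic ring; the only step shown concerns the sulfonyl sulfur, so it offers no guide to the effect of swapping isobutyl for 2-chloro-4-fluorophenyl. With nothing to point in either direction, the expected step of a 1.1-fold higher number from compound 1 to compound 4 (0.05 log units; within the scatter) is small, no larger than the scatter. Compound 4 is therefore estimated to give 65 uL/min in this assay, with the expected range running from 30 uL/min to 140 uL/min.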

Compound 4, intrinsic clearance in a liver preparation (reported as CLH), per the amount of preparation that the assay uses: 53 uL/min
Compound 4: middle estimate off by 1.2-fold (0.09 log units), on the high side; the measured number falls inside the stated range.
By their numbers in this assay, from the lowest: compounds 4, 3, 1 and 2 (each within the scatter of the next).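

Within the data shown here, until this result, the only single change read was on the sulfonyl sulfur; this is the first reading at the oxygen on an aromatic ring. In this assay the exchange of isobutyl, which has no ring, for 2-chloro-4-fluorophenyl, which brings a six-membered aromatic ring with a fluorine and a chlorine, gives a 1.1-fold lower number from compound 1 to compound 4 (0.04 log units; within the scatter) and so leaves the two compounds indistinguishable, showing that even this large a change in the group at this place need not shift the number beyond the scatter. Nothing in the data shown accounts for this outcome.

Among the compounds shown, only this one replacement for isobutyl can be read at this oxygen, so it remains open whether a small methyl, or a chain ending in a carboxylic acid or an amine, would move the number beyond the scatter. Also open, on these data alone, is whether 2-chloro-4-fluorophenyl would give the same reading with the cyclopropylamino group of compound 3 on the sulfonyl sulfur in place of the cyclopropylmethyl group of compound 1.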